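Shortening the Chain from Hexyl to Propyl

The source may report more compounds than this note shows. Statements on the series, on what has been measured and on what is new or still open speak of the compounds shown alone.

Of the compounds shown here, three have been measured. Compound 1, `Cc1nc(N)sc1CCCN/C(N)=N/C(=O)NC1CCCCC1`, gives 170 nM in an assay on membranes from Sf9 cells for displacement of a labelled ligand from histamine H2 receptor (Homo sapiens), read by scintillation counting, with a stated time of 60 min; on this read-out lower numbers stand for stronger inhibition and higher numbers for weaker inhibition. Compound 2, `Cc1nc(N)sc1CCCN/C(N)=N/C(=O)NC(C)c1ccc(OC(F)(F)F)cc1`, gives 126 nM. Compound 3, `CCCCCCNC(=O)/N=C(\N)NCCCc1sc(N)nc1C`, gives 28.8 nM.

On these numbers compound 3 stands lowest, and since its gaps to both other compounds are beyond the scatter it is the strongest binder of the three; compound 2 lies nearer to it and compound 1 furthest away. All three share the same core and differ only in the group carried on the amide-type nitrogen.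

Compound 4, `CCCNC(=O)/N=C(\N)NCCCc1sc(N)nc1C`, keeps that core and differs from compound 3 in one place: hydrogen in place of propyl on a saturated chain carbon, three bonds along the chain from an amide-type nitrogen.

Among the compounds with values here, only one measured step concerns the same nitrogen: a 5.9-fold lower number from compound 1 to compound 3 (0.77 log units; beyond the scatter), where a straight hexyl chain replaced a cyclohexyl ring. Within the data shown here, that step shows the group on this nitrogen matters, but no measured pair shows what shortening the straight chain does, and compound 2, with an aryl-bearing group, sits between the two. Removing three chain carbons is therefore expected to cost some binding, a modest step upward in this assay, with wide uncertainty. For compound 4 the expected value is 100 nM, between 30 nM and 350 nM, corresponding to an estimated step of a 3.5-fold higher number from compound 3 to compound 4 (0.54 log units; beyond the scatter).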

Compound 4, inhibition constant: 105 nM
For compound 4 the middle estimate is 1.1-fold (0.02 log units) below the measured one; low and high end bracket the measured number.
By their numbers in this assay, from the lowest: compound 3; then compounds 4, 2 and 1 (each within the scatter of the next).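

Chain length on this nitrogen now has a measured effect of its own: in this assay, shortening the straight chain from hexyl to propyl gives a 3.6-fold higher number from compound 3 to compound 4 (0.56 log units; beyond the scatter) on the same core, so the longer chain goes with the stronger binding. The propyl chain and the cyclohexyl ring, by contrast, cannot be told apart on these numbers, as the comparison shows with a 1.6-fold lower number from compound 1 to compound 4 (0.21 log units; within the scatter) and so no ranking of the two follows. Among these three groups, then, only the hexyl chain stands apart, and nothing available here explains why the shorter chain loses binding.

Butyl and pentyl chains, along with a longer chain such as octyl, would be needed to show whether binding improves steadily with each added carbon, reaches a best length or falls away again. Also open, from the compounds shown here alone, is whether a hexyl chain carrying an amine or a hydroxyl group would keep the binding of compound 3, which would show how much the plain carbon chain itself matters.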